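The source may report more compounds than this note shows. Statements on the series, on what has been measured and on what is new or still open speak of the compounds shown alone.

Measured compounds in a functional assay on MCF7 cells (Homo sapiens) for cytotoxicity; a higher number here means a weaker inhibitor, a lower number a stronger inhibitor:
compound 1 , `O=c1c2ccccc2c(Nc2n[nH]c3ccccc23)nn1-c1ccccc1`: "not determined" (no result reported)
compound 2 , `COc1ccc(-n2nc(Nc3cc(C)[nH]n3)c3ccccc3c2=O)cc1`: 3600 nM
compound 3 , `CC(=O)Nc1ccc(Cn2nc(Nc3cc(C)[nH]n3)c3ccccc3c2=O)cc1`: > 30000 nM

Compound 1 carries no result in this assay. Going by the values given here, compound 2 is the only member of the series with a single number, and compound 3 is reported only as a limit. For compound 3 the value > 30000 nM is a limit of the assay and not a number; it is the entry described by the limit of > 30000 nM in this assay, at which 1 of the 3 values shown sits, the point at which one of the three values shown sits. Among the compounds with values here, compound 3 therefore stands at the weak end of what this assay can resolve, with no measured step to any other compound.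

The unmeasured compound 4 , `Cc1cc(Nc2nn(Cc3ccc([N+](=O)[O-])cc3)c(=O)c3ccccc23)n[nH]1`, differs from compound 3 in one place: nitro in place of acetamido on an aromatic carbon. The new group sits on an aromatic carbon of a six-membered aromatic ring of carbon only, in the same place on the benzyl arm of the shared core.

Within the data shown here, with no measured step between compounds that differ in one place, the size of the step in this assay has no precedent. The change is expected to give at most a modest shift, in either direction, and quite possibly none beyond the scatter. Compound 4 is expected to remain weak, with an at least 1.2-fold lower number from compound 3 to compound 4 (0.07 log units; that floor lies within the scatter) read against a limit. The estimate for compound 4 is 25000 nM, in the range 6000 nM to 100000 nM.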

Compound 4, half-maximal inhibitory concentration: > 30000 nM
Compound 4: no number, only a limit; the forecaster's own chance of this, stated with the estimate: 55%; at least 1.2-fold (0.07 log units) between middle value and limit.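

In this assay, going by these compounds alone, compound 3 and compound 4 both sit at a limit of the assay, and no step between them can be read: the limit of > 30000 nM in this assay, at which 2 of the 4 values shown sit.

The compounds shown leave open whether nitro in place of acetamido on an aromatic carbon changes the read-out in this assay at all, and what single number either compound would give.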